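The compounds below may be only part of what the source reports. "The series", "measured", "known", "first", "only" and "open" are said of these compounds alone.

Compound 1 `COC(=O)[C@@]1(C)CCC=C2[C@@H]1CC[C@@H](C)[C@]2(C)Cc1c[nH]c2ccccc12` is the starting point of this small set. In a functional assay on T47D cells (Homo sapiens) for inhibition, read by sulforhodamine B assay, with a stated time of 48 h (a lower number here means a stronger inhibitor of growth, a higher number a weaker inhibitor of growth), compound 1 gives 4200 nM. Compound 2 `COC(=O)[C@@]1(C)CCC=C2[C@@H]1CC[C@@H](C)[C@]2(C)Cc1c[nH]c2c(C)cccc12` carries a methyl on the benzene part of the core and gives 18000 nM; compound 3 `COC(=O)[C@@]1(C)CCC=C2[C@@H]1CC[C@@H](C)[C@]2(C)Cc1c[nH]c2c(Cl)cccc12` carries a chloro at the same place and gives 24000 nM. Compound 2 thus stands second highest of the three numbers: its nearest neighbour is compound 3, a 1.3-fold higher number from compound 2 to compound 3 (0.12 log units; within the scatter), while the furthest is compound 1, a 4.3-fold higher number from compound 1 to compound 2 (0.63 log units; beyond the scatter).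

Compound 4 `COC(=O)[C@@]1(C)CCC=C2[C@@H]1CC[C@@H](C)[C@]2(C)Cc1c(C)[nH]c2c(C)cccc12` differs from compound 2 by methyl in place of hydrogen on an aromatic carbon, on an aromatic carbon of a five-membered aromatic ring with one nitrogen, part of a fused system of two rings, next to the ring nitrogen and next to the ring atom that bears a large group. Going by the values given here, no measured step touches this ring. Among the compounds with values here, the only related steps are additions of small groups to the benzene part of the core, a 4.3-fold higher number from compound 1 to compound 2 (0.63 log units; beyond the scatter) and a 5.7-fold higher number from compound 1 to compound 3 (0.76 log units; beyond the scatter), both modest and both toward higher numbers. A step of similar size or smaller, toward a higher number or none beyond the scatter, is therefore expected for a 1.6-fold higher number from compound 2 to compound 4 (0.19 log units; within the scatter). Compound 4 is expected to give 28000 nM, within a range from 10000 nM to 80000 nM.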

Compound 4, concentration for 50% growth inhibition: 19000 nM
Compound 4: middle estimate off by 1.5-fold (0.17 log units), on the high side; low and high end bracket the measured number.
By their numbers in this assay, from the lowest: compound 1; then compounds 2, 4 and 3 (each within the scatter of the next).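

The earlier steps shown here all changed the benzene part of the core, whereas this one reaches the five-membered aromatic ring with one nitrogen, at the carbon next to the ring nitrogen. In this assay, methyl in place of hydrogen here gives a 1.1-fold higher number from compound 2 to compound 4 (0.02 log units; within the scatter), so this carbon carries a methyl without a change beyond the scatter, while methyl on the benzene part gave a 4.3-fold higher number from compound 1 to compound 2 (0.63 log units; beyond the scatter). No measurement available here explains why the two places differ.

The compounds shown leave open whether an amine, a carboxylic acid or a longer chain on this carbon would also leave the number unchanged, and whether methyl here would behave the same on the core of compound 1, without the methyl on the benzene part. They also leave open whether any group at this carbon could bring the number closer to that of compound 1, at 4200 nM.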